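From 2-fluorophenyl to 4-methoxyphenyl on a shared core

The source may hold more compounds than are shown below. What is called first, only, known or untested is meant among the compounds shown, and "the series" means these compounds.

In a physicochemical assay, with a stated time of 6 min (on this read-out lower numbers stand for stronger inhibition and higher numbers for weaker inhibition), compound 1 (`O=C(Nc1ccc(I)cc1)Nc1nc(-c2cc3ccccc3o2)cs1`) gives 62000 nM and compound 2 (`O=C(Nc1nc(-c2cc3ccccc3o2)cs1)Nc1ccccc1F`) gives 2630 nM as the lower of the two numbers. Among the measured compounds shown here, the only measured step is large: a 24-fold lower number from compound 1 to compound 2 (1.37 log units; beyond the scatter) with 2-fluorophenyl in place of 4-iodophenyl on an amide-type nitrogen. Compound 3 (`COc1ccc(NC(=O)Nc2nc(-c3cc4ccccc4o3)cs2)cc1`) has 4-methoxyphenyl in place of 2-fluorophenyl at that same place (4-methoxyphenyl in place of 2-fluorophenyl on an amide-type nitrogen). The measured step bears on this change only indirectly, since 4-methoxyphenyl itself has not been measured. Compound 3 resembles compound 1 (62000 nM) in leaving 2-fluorophenyl behind, so part of the large step may be given back, and a moderate rise in the number is expected in this assay rather than a fall. The expected change is a 4.6-fold higher number from compound 2 to compound 3 (0.66 log units; beyond the scatter) as estimated here. Compound 3 is estimated at 12000 nM with an expected range from 2500 nM to 60000 nM in this estimate.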

Compound 3, half-maximal inhibitory concentration: 17400 nM
Beside the measured number, compound 3's estimate is 1.5-fold (0.16 log units) below it; measured number inside the range.
By their numbers in this assay, from the lowest: compound 2; then compound 3; then compound 1.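

In this assay, 4-methoxyphenyl on the amide-type nitrogen gives the middle number of the three: the change from 2-fluorophenyl gives a 6.6-fold higher number from compound 2 to compound 3 (0.82 log units; beyond the scatter), while methoxy in place of iodo on an aromatic carbon gives a 3.6-fold lower number from compound 1 to compound 3 (0.55 log units; beyond the scatter). The position therefore does not behave as a simple switch, since a third group gives a distinct intermediate number, with both new steps beyond the scatter. 2-Fluorophenyl still gives the lowest number of the three, but no supporting data explain this order.

The compounds shown do not separate the identity of a group from where it stands on the phenyl ring, a question that 2-methoxyphenyl and 4-fluorophenyl would address. As far as these compounds go, it also remains open whether an amine or a carboxylic acid on that ring could match or pass compound 2 at 2630 nM.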